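Swapping the propynyl of compound 2 for a methoxy group

The source may report more compounds than this note shows. Statements on the series, on what has been measured and on what is new or still open speak of the compounds shown alone.

Of the compounds shown here, two sharing one core have been measured in a functional assay on cells for agonist activity at Free fatty acid receptor 1 (Homo sapiens), read by calcium flux; on this read-out lower numbers stand for an effect already at smaller amounts and higher numbers for an effect only at larger amounts of compound. Compound 1 `Cc1cccc(C)c1-c1cccc(COc2ccc(C(CC(=O)O)C3CC3)s2)c1` gives 3920 nM. Compound 2 `CC#CC(CC(=O)O)c1ccc(OCc2cccc(-c3c(C)cccc3C)c2)s1` gives 210 nM, the lowest of the two numbers; the nearest is compound 1, and the step of a 19-fold lower number from compound 1 to compound 2 (1.27 log units; beyond the scatter) lies beyond the scatter. Compound 3 `COC(CC(=O)O)c1ccc(OCc2cccc(-c3c(C)cccc3C)c2)s1` is not yet measured. It differs from compound 2 by methoxy in place of prop-1-yn-1-yl on a saturated chain carbon bound to an aromatic carbon and a saturated chain carbon. For the measured compounds named here, the only measured step that bears on this position is a 19-fold lower number from compound 1 to compound 2 (1.27 log units; beyond the scatter), where a group of different shape at the same carbon moved the number a long way. With the prop-1-yn-1-yl gone and a methoxy group in its place, a sizeable step upward in this assay is expected, though its exact size is uncertain. Compound 3 is therefore estimated at 2500 nM, with a range from 600 nM to 10000 nM. The expected step is a 12-fold higher number from compound 2 to compound 3 (1.08 log units; beyond the scatter).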

Compound 3, half-maximal effective concentration: 210 nM
Compound 3: the middle estimate sits 12-fold (1.08 log units) above what was measured; the measured number lies below the stated range.
By their numbers in this assay, from the lowest: compounds 2 and 3 (each within the scatter of the next); then compound 1.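

In this assay, the step of no change at the digits printed from compound 2 to compound 3 (within the scatter) shows that the triple bond of prop-1-yn-1-yl is not needed at this saturated chain carbon: methoxy, which brings an oxygen and a hydrogen-bond acceptor, gives the same number with one heavy atom fewer. Cyclopropyl now stands apart from two unlike groups rather than one, since a 19-fold lower number from compound 1 to compound 3 (1.27 log units; beyond the scatter) matches the size of the earlier step to compound 2. Nothing measured here explains this result.

As far as these compounds go, it remains open whether the number would hold with other groups on this carbon, such as a hydroxyl, an amine or a longer chain. It is also unclear whether ethoxy would keep the number of compound 3 or move towards that of compound 1.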